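The compounds below may be only part of what the source reports. "The series", "measured", "known", "first", "only" and "open" are said of these compounds alone.

Measured compounds:
compound 1, `COc1ccc(-c2nc(CCc3cccc(Cl)c3)nc3ccsc23)cn1`; in an ADME assay on cells (Homo sapiens) for cytotoxicity, read by resazurin assay, with a stated time of 5 days (on this read-out lower numbers stand for higher toxicity in this test and higher numbers for lower toxicity in this test), compound 1 reports a limit, > 50000 nM.
compound 2, `O=S(=O)(Cc1nc(-c2ccc(Cl)nc2)c2sccc2n1)c1cccc(Cl)c1`; in this assay compound 2 gives 70000 nM.
compound 3, `COc1ccc(-c2nc(C3(S(=O)(=O)c4cccc(Cl)c4)CC3)nc3ccsc23)cn1`; in this assay compound 3 reports a limit, > 50000 nM.

For the measured compounds named here, compound 2 holds the only number in the set; the other two results are limits, as the limit of > 50000 nM in this assay, at which 2 of the 3 values shown sit, records. Compound 4, `O=c1ccc(-c2nc(CS(=O)(=O)c3cccc(Cl)c3)nc3ccsc23)c[nH]1`, is not yet measured. It differs from compound 2 in one place: a group of 7 heavy atoms (5 carbon, 1 nitrogen, 1 oxygen; one six-membered aromatic ring with 1 hetero atom) in place of a group of 7 heavy atoms (5 carbon, 1 nitrogen, 1 chlorine; one six-membered aromatic ring with 1 hetero atom), on an aromatic carbon. Going by the values given here, no step between measured compounds is available, so nothing in these data connects this change to cytotoxicity. Given how weakly toxic all three measured compounds are, the expected step is a 1.2-fold lower number from compound 2 to compound 4 (0.07 log units; within the scatter), none beyond the scatter. Compound 4 is estimated at 60000 nM, between 30000 nM and 120000 nM, with a fair chance that only a limit is reported.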

Compound 4, half-maximal cytotoxic concentration: > 50000 nM
Compound 4: no number, only a limit; the forecaster's own chance of this, stated with the estimate: 50%; the middle value lies beyond the limit too.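

For the compounds shown here, no step from compound 2 to compound 4 can be read, as compound 4 gives only a limit in this assay: the limit of > 50000 nM in this assay, at which 3 of the 4 values shown sit.

As far as these compounds go, whether replacing the 6-chloropyridin-3-yl group changes the result in this assay at all stays open.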